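Trimming a Branch from the Ketone Side Chain

A few compounds are considered here, and "the series" means these few. Any claim that something is new, unique, unknown or untested is made for them only; others in the source may bear on it.

Measured so far:
Compound 1, `Cc1cc(C(=O)O)ccc1OCCCCOc1ccc(C(=O)CC(C)C)c(O)c1C`, gives 83.9%.
Compound 2, `CCC(=O)c1ccc(OCCCCOc2cc(C(=O)O)ccc2OC)c(C)c1O`, gives 72.6%.
Compound 3, `COc1ccc(C(=O)O)cc1OCCCCOc1ccc(C(=O)C(C)C)c(O)c1C`, gives 66.6%.

These numbers come from an assay on HEK293 cells for positive allosteric modulation of metabotropic glutamate receptor 2 (Rattus norvegicus), read by thallium flux, with a stated time of 2.5 min; a lower number here means a smaller maximal response, a higher number a larger maximal response. Compound 1 stands highest of the three, and its distance to compound 2 and to compound 3 lies beyond the usual scatter. Compound 4, `CCCC(=O)c1ccc(OCCCCOc2ccc(C(=O)O)cc2C)c(C)c1O`, is not yet measured. It differs from compound 1 by hydrogen in place of methyl on a saturated chain carbon bound to two saturated chain carbons. A change of the same kind, (hydrogen in place of methyl on a saturated chain carbon bound to a carbonyl carbon and a saturated chain carbon), links compound 3 to compound 2, and there the step was a number 6 percentage points higher from compound 3 to compound 2 (within the scatter). The two places are not identical: in the measured pair the carbon carrying the change is bound to a carbonyl carbon and a saturated chain carbon, while in the new pair it is bound to two saturated chain carbons. How the core of compound 1 differs from that of compound 3 is not broken down here. Because the measured pair moved only a number 6 percentage points higher from compound 3 to compound 2 (within the scatter), a similarly small step, a number 1.9 percentage points lower from compound 1 to compound 4 (within the scatter), is expected from the same kind of change. Compound 4 is therefore estimated at 82%, likely between 68% and 96%.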

Compound 4, largest response reached (reported as percent of maximum), in percent of the reference or control that the assay uses: 79.3%
Compound 4: middle estimate off by 2.7 percentage points, on the high side; the measured number falls inside the stated range.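

In this assay, the change from isobutylcarbonyl to propylcarbonyl gives a number 4.6 percentage points lower from compound 1 to compound 4 (within the scatter). Set beside the earlier case, removing a methyl from this side chain gives a comparable result on both cores: the same change on two cores in this assay, a number 6 percentage points higher (within the scatter) from compound 3 to compound 2 and a number 4.6 percentage points lower (within the scatter) from compound 1 to compound 4, 10.6 percentage points apart, within the scatter of two such steps This shows that, in these two pairs, the change left the maximal response within the usual scatter, but no direction can be read from steps this small, and the carbon losing the methyl is not the same kind of carbon in the two pairs, so they do not show that the change would stay this small on any other core or at any other place on the chain.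

The compounds shown leave open what happens when the ketone side chain is made longer or ends in a ring such as cyclopentyl. They also leave open how the maximal response would move if the carboxylic acid were replaced by an amide or an amine.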